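The source may hold more compounds than are shown below. What is called first, only, known or untested is meant among the compounds shown, and "the series" means these compounds.

Compound 2 `COc1ccc(/C(=C\c2cn(C(C)=O)c3ccc(OCc4ccccc4)cc23)C(=O)O)cc1OC` gives 1050 nM in a functional assay on DU-145 cells (Homo sapiens) for cytotoxicity, read by MTT assay, with a stated time of 72 h (on this read-out higher numbers stand for weaker inhibition and lower numbers for stronger inhibition), and stands at the upper of the two numbers shown, though only by a gap within the scatter. Compound 1 `COc1ccccc1/C(=C\c1cn(C(C)=O)c2ccc(OCc3ccccc3)cc12)C(=O)O` gives 1010 nM, and the step of a 1.0-fold higher number from compound 1 to compound 2 (0.02 log units; within the scatter) shows how little a change on this ring moved the read-out. Compound 3 `COc1ccc(/C(=C\c2cn(C(C)=O)c3ccc(OCc4ccccc4)cc23)C(=O)O)cc1` carries the change (hydrogen in place of methoxy on an aromatic carbon), hydrogen in place of methoxy on an aromatic carbon. Among the measured compounds shown here, since the one step that bears on this ring lay within the scatter, the expected step of no change at the digits printed from compound 2 to compound 3 (within the scatter) in this assay is none beyond the scatter. Compound 3 is therefore expected to give 1050 nM, between 500 nM and 2200 nM.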

Compound 3, half-maximal inhibitory concentration: 910 nM
Compound 3: the middle estimate sits 1.2-fold (0.06 log units) above what was measured; the range from low to high includes it.
By their numbers in this assay, from the lowest: compounds 3, 1 and 2 (each within the scatter of the next).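

In this assay, going from 3,4-dimethoxyphenyl to 4-methoxyphenyl removes a methoxy group without a shift beyond the scatter (a 1.2-fold lower number from compound 2 to compound 3 (0.06 log units; within the scatter)). Moving the single methoxy group from 2-methoxyphenyl to 4-methoxyphenyl also stays within the scatter (a 1.1-fold lower number from compound 1 to compound 3 (0.05 log units; within the scatter)), so all three methoxy patterns read alike here. No evidence is available on what lies behind this.

Every compound shown keeps at least one methoxy group on this ring. As far as these compounds go, what an unsubstituted phenyl ring, or an amine or a nitrile on it, would give remains open.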